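This account rests on a few compounds, and the source may have more. Where it says the series, first, only, none or still open, it means among the compounds named here.

Going by the values given here, compound 3 `O=c1[nH]c2ccccc2n1CCCCN1CCN(C(c2ccccc2)c2ccccc2)CC1` gives 180 nM in an assay on RPMI-8226 cells for antagonist activity at P2X purinoceptor 7 (Homo sapiens), read by calcium flux (a lower number here means a stronger inhibitor, a higher number a weaker inhibitor), the only number among the three measured results. The other two results are limits rather than numbers: the limit of > 10000 nM in this assay, at which 2 of the 3 values shown sit. Compound 1 `O=c1[nH]c2ccccc2n1CCCN1CCN(S(=O)(=O)c2ccc([N+](=O)[O-])cc2)CC1` sits at a limit of this assay, > 10000 nM. Compound 2 `O=c1[nH]c2ccccc2n1CCCN1CCN(S(=O)(=O)c2ccc(F)cc2)CC1` likewise sits at a limit, > 10000 nM. The step that the two limits leave unreadable from compound 1 to compound 2 therefore cannot be sized. Compound 4 `Cc1ccc2ccn(CCCCN3CCN(C(c4ccccc4)c4ccccc4)CC3)c2c1` differs from compound 3 by a group of 10 heavy atoms (9 carbon, 1 nitrogen; one five-membered aromatic ring with 1 hetero atom, one six-membered aromatic ring of carbon only) in place of a group of 10 heavy atoms (7 carbon, 2 nitrogen, 1 oxygen; one five-membered aromatic ring with 2 hetero atoms, one six-membered aromatic ring of carbon only), on a saturated chain carbon, four bonds along the chain from an amine nitrogen in a ring. Among the compounds with values here, no measured step shares this change, so the only guide is where compound 3 stands. The step is expected to be small, a 1.7-fold higher number from compound 3 to compound 4 (0.22 log units; within the scatter), though with wide uncertainty. Compound 4 is estimated at 300 nM, with a range from 60 nM to 1500 nM.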

Compound 4, half-maximal inhibitory concentration: 6500 nM
Beside the measured number, compound 4's estimate is 22-fold (1.34 log units) below it, and the stated range ends below it.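

In this assay, going by these compounds alone, the change on this saturated chain carbon gives a 36-fold higher number from compound 3 to compound 4 (1.56 log units; beyond the scatter) and is the first step that can be sized, since the step between the two limits cannot be read. So at this place on the chain, the result depends strongly on which group is attached. The group that enters has 0 hydrogen-bond donors and 1 acceptor, against 1 and 2 in the group that leaves, but no measurement here shows which difference drives the step. On these data alone, whether an amide or a carboxylic acid at this place would give a number close to that of compound 3 stays open. So does the effect of a longer chain on either group.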